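Butyl in Place of Methoxycarbonyl on a Ring Nitrogen

The source may hold more compounds than are shown below. What is called first, only, known or untested is meant among the compounds shown, and "the series" means these compounds.

Compound 1 `CCCCCC(=O)c1ccc(OCCCN2CCN(C(=O)OC)CC2)cc1` gives 12000 nM in an assay on isolated protein for binding affinity to histamine H2 receptor (Homo sapiens); on this read-out higher numbers stand for weaker inhibition and lower numbers for stronger inhibition.
Compound 2 `CCCCCC(=O)c1ccc(OCCCN2CCN(C(=O)C(C)(C)O)CC2)cc1` gives 24500 nM in this assay.

Compound 1 holds the lowest of the two numbers; its nearest neighbour is compound 2, reached by a 2.0-fold higher number from compound 1 to compound 2 (0.31 log units; beyond the scatter). Compound 3 `CCCCCC(=O)c1ccc(OCCCN2CCN(CCCC)CC2)cc1` differs from compound 1 as follows: butyl in place of methoxycarbonyl on an amine nitrogen in a ring. Going by the values given here, the only measured step alters the group on the carbonyl carbon and keeps the methoxycarbonyl, so it does not bear on removing it; the size of this step is unknown from the data. Compound 3 is therefore expected at 7000 nM, a step of a 1.7-fold lower number from compound 1 to compound 3 (0.23 log units; within the scatter), with a range from 1500 nM to 35000 nM.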

Compound 3, inhibition constant: 7590 nM
The estimate for compound 3 lay 1.1-fold (0.04 log units) below the measured number, within the range that was stated.
By their numbers in this assay, from the lowest: compounds 3 and 1 (each within the scatter of the next); then compound 2.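

In this assay, butyl takes the place of methoxycarbonyl on the amine nitrogen in the ring with a 1.6-fold lower number from compound 1 to compound 3 (0.20 log units; within the scatter) and so this position holds a group without a carbonyl, with no hydrogen-bond acceptors, and shows no change that stands clear of the scatter. Butyl in place of (1-hydroxy-1-methylethyl)carbonyl gives a 3.2-fold lower number from compound 2 to compound 3 (0.51 log units; beyond the scatter) and that step does stand clear of it. Nothing at hand speaks to the cause of either step.

On these data alone, what a longer chain, a benzyl group or a free amine hydrogen on this nitrogen would give stays open. So does whether any group here reaches much lower numbers.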